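The compounds below may be only part of what the source reports. "The series", "measured", "known", "first", "only" and "open" are said of these compounds alone.

In a physicochemical assay for solubility, read by chemiluminescence, measured as kinetic solubility (a higher number here means a more soluble compound, a lower number a less soluble compound), compound 1 `O=C(C1CCCN1)N1CCC2(CCN(c3nccc(NCc4ccc(Cl)cc4Cl)n3)CC2)C1` gives 79 ug/mL and compound 2 `O=C(C1CCCNC1)N1CCC2(CCN(c3nccc(NCc4ccc(Cl)cc4Cl)n3)CC2)C1` gives 186 ug/mL as the higher of the two numbers. Compound 3 `O=C(C1CCCCC1)N1CCC2(CCN(c3nccc(NCc4ccc(Cl)cc4Cl)n3)CC2)C1` carries cyclohexyl in place of piperidin-3-yl on a carbonyl carbon and has yet to be measured. Going by the values given here, the only measured step (a 2.4-fold higher number from compound 1 to compound 2 (0.37 log units; beyond the scatter)) exchanges pyrrolidin-2-yl for piperidin-3-yl, so it bears only loosely, and no measured compound lacks a nitrogen in this ring. A fall larger than that step is expected in this assay and is estimated as a 6.2-fold lower number from compound 2 to compound 3 (0.79 log units; beyond the scatter). For compound 3 the expected value is 30 ug/mL, within an estimated range of 7 ug/mL to 100 ug/mL.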

Compound 3, solubility: 3 ug/mL
Compound 3: middle estimate off by 10-fold (1.00 log units), on the high side; measured number below the stated range.
By their numbers in this assay, from the lowest: compound 3; then compound 1; then compound 2.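

In this assay, the nitrogen-free ring stands well apart from both nitrogen-bearing rings at this position: cyclohexyl in place of piperidin-3-yl gives a 62-fold lower number from compound 2 to compound 3 (1.79 log units; beyond the scatter), and cyclohexyl in place of pyrrolidin-2-yl gives a 26-fold lower number from compound 1 to compound 3 (1.42 log units; beyond the scatter). Both steps are large, whereas exchanging one nitrogen-bearing ring for the other gave only a modest step. Nothing measured here explains the fall. From the compounds shown here alone, it remains open whether a ring oxygen, as in tetrahydropyranyl, would behave like the ring nitrogen. The same holds for an amine carried on the cyclohexyl ring.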